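This account rests on a few compounds, and the source may have more. Where it says the series, first, only, none or still open, it means among the compounds named here.

Compound 1, `Fc1cccc(NC(=S)N/N=C/c2ccc3ccccc3n2)c1`, gives 79900 nM in a functional assay on SGC-7901 cells (Homo sapiens) for antiproliferative activity, read by sulforhodamine B assay, with a stated time of 72 h; a higher number here means a weaker inhibitor, a lower number a stronger inhibitor.
Compound 2, `S=C(N/N=C/c1ccc2ccccc2n1)Nc1cccc(Cl)c1`, gives 61300 nM in this assay.
Compound 3, `Cc1ccc(NC(=S)N/N=C/c2ccc3ccccc3n2)cc1`, gives 92900 nM in this assay.

Compound 3 stands with the highest of the three numbers, yet its steps to the other two compounds are both within the scatter, so none of the three can be ranked against another. Compound 4, `S=C(N/N=C/c1ccc2ccccc2n1)Nc1ccc(Cl)cc1`, differs from compound 3 in one place: chloro in place of methyl on an aromatic carbon. Among the compounds with values here, three measured steps bear on this change. The halogen exchange a 1.3-fold lower number from compound 1 to compound 2 (0.12 log units; within the scatter) and the two steps that trade a halophenyl for 4-methylphenyl, a 1.2-fold higher number from compound 1 to compound 3 (0.07 log units; within the scatter) and a 1.5-fold higher number from compound 2 to compound 3 (0.18 log units; within the scatter), all stay within the scatter. Since neither swapping one halogen for another nor moving from halogen to methyl shifted the number beyond the scatter, the change from methyl to chloro is expected to do no more. Compound 4 is therefore expected to sit close by, the estimated step being a 1.3-fold lower number from compound 3 to compound 4 (0.12 log units; within the scatter). The estimate for compound 4 in this assay is 70000 nM, with a range from 32000 nM to 150000 nM.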

Compound 4, half-maximal inhibitory concentration: 87600 nM
Compound 4: middle estimate off by 1.3-fold (0.10 log units), on the low side; measured number inside the range.
By their numbers in this assay, from the lowest: compounds 2, 1, 4 and 3 (each within the scatter of the next).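

The direct exchange on the aromatic carbon para to a large group, 4-methylphenyl to 4-chlorophenyl, gives a 1.1-fold lower number from compound 3 to compound 4 (0.03 log units; within the scatter) in this assay, so methyl and chloro at this position cannot be told apart here. Compound 4 also supplies the first pair carrying the same halogen at two ring places, a 1.4-fold higher number from compound 2 to compound 4 (0.16 log units; within the scatter), while a 1.1-fold higher number from compound 1 to compound 4 (0.04 log units; within the scatter) combines a change of halogen with a change of place, and both steps stay within the scatter, leaving all four compounds unranked. Nothing available offers an explanation for these results. Going by these compounds, what remains open is whether a quite different group at this position, such as an amine, a carboxylic acid or a longer chain, would move the number beyond the scatter. The compounds shown also leave open whether any change away from this ring would do so.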